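Saturating the cyanoethenyl chain on a shared core

The source may report more compounds than this note shows. Statements on the series, on what has been measured and on what is new or still open speak of the compounds shown alone.

In an ADME assay on TZM cells (Homo sapiens) for cytotoxicity, read by XTT assay, with a stated time of 4 days (a lower number here means that less compound is tolerated, a higher number that more compound is tolerated), compound 3 `Cc1cc(/C=C/C#N)cc(C)c1Oc1cc(Nc2ccc(C#N)cc2)c(N)cc1C(=O)O` gives 14900 nM, the highest of the two numbers shown. Its nearest neighbour, compound 1 `Cc1cc(CCC#N)cc(C)c1Oc1cc(Nc2ccc(C#N)cc2)c(N)cc1S(N)(=O)=O`, gives 11100 nM in this assay, a gap that lies within the scatter. For compound 2 `Cc1cc(CCC#N)cc(C)c1Oc1cc(Nc2ccc(C#N)cc2)c(N)cc1C(=O)NN` this assay reports only a limit, > 22700 nM. Among the compounds with values here, the single measured step, an at least 2.0-fold higher number from compound 1 to compound 2 (0.31 log units; beyond the scatter), concerns a different part of the core and rests on a limit, (the limit of > 22700 nM in this assay, at which 1 of the 3 values shown sits), so only its lower bound is known.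

Compound 4 `Cc1cc(CCC#N)cc(C)c1Oc1cc(Nc2ccc(C#N)cc2)c(N)cc1C(=O)O` differs from compound 3 by 2-cyanoethyl in place of 2-cyanoethenyl on an aromatic carbon. Within the data shown here, no measured step involves this change, so the data give no direction for it; the expected step of a 1.1-fold lower number from compound 3 to compound 4 (0.03 log units; within the scatter) is therefore estimated to stay within the scatter. Compound 4 is expected to give about 14000 nM in this assay, in a range from 7000 nM to 28000 nM.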

Compound 4, half-maximal cytotoxic concentration: 14300 nM
For compound 4 the middle estimate is 1.0-fold (0.01 log units) below the measured one; low and high end bracket the measured number.
By their numbers in this assay, from the lowest: compounds 1, 4 and 3 (each within the scatter of the next). At a limit, above all of these: compound 2.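

In this assay, within the data shown here, the change at this position can now be read directly for the first time: a 1.0-fold lower number from compound 3 to compound 4 (0.02 log units; within the scatter), so on the carboxy-bearing core, 2-cyanoethyl in place of 2-cyanoethenyl has no effect that can be told from the scatter. With the 2-cyanoethyl chain held fixed, the other end of the core can also be compared: a 1.3-fold higher number from compound 1 to compound 4 (0.11 log units; within the scatter), so carboxy and sulfamoyl cannot be told apart here. The remaining step, an at least 1.5-fold lower number from compound 2 to compound 4 (0.20 log units; that floor lies within the scatter), gives only a floor that lies within the scatter, so it fixes no real gap: the limit of > 22700 nM in this assay, at which 1 of the 4 values shown sits.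

On these data alone, the saturation step is read on a carboxy-bearing core alone, so it remains open whether it would hold with sulfamoyl or aminocarbamoyl there. As far as these compounds go, it is also open whether a longer chain, or an amine in place of the nitrile, would move the number beyond the scatter.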